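The source may report more compounds than this note shows. Statements on the series, on what has been measured and on what is new or still open speak of the compounds shown alone.

All four compounds share one core, shown with compound 1 `CC(=O)NN=C1C(Cl)=C(Cl)C(Cl)=C1Cl`, and differ only in the tail joined to it through the hydrazone. For compound 1 the result in a functional assay on MM1.S cells (Homo sapiens) for cytotoxicity, read by MTT assay, with a stated time of 48 h (a lower number here means a stronger inhibitor, a higher number a weaker inhibitor), is recorded as "not determined" (no result reported), so it contributes no number. Compound 3 `CC(C)(C)C(=O)NN=C1C(Cl)=C(Cl)C(Cl)=C1Cl` carries a bulky amide tail, and in this assay compound 3 gives 2000 nM. Compound 2 `Fc1cccc(NN=C2C(Cl)=C(Cl)C(Cl)=C2Cl)c1` carries an aromatic ring bearing a fluoro group, and in this assay compound 2 gives 1500 nM. That is the lower of the two numbers available, but the gap to compound 3 lies within the usual scatter of repeated measurements, so the two cannot be ranked against each other.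

Compound 4 `FC(F)(F)c1cccc(NN=C2C(Cl)=C(Cl)C(Cl)=C2Cl)c1` has not yet been measured. It differs from compound 2 in one place: trifluoromethyl in place of fluoro on an aromatic carbon. For the measured compounds named here, no measured pair in this set shows what such a change does, so there is no comparable step to lean on. The expectation for compound 4 is therefore a modest shift toward a lower number, with a step of a 1.5-fold lower number from compound 2 to compound 4 (0.18 log units; within the scatter) that may well not exceed the scatter. In this assay compound 4 is estimated at 1000 nM, within a range from 400 nM to 2500 nM.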

Compound 4, half-maximal inhibitory concentration: 1000 nM
Estimate against measurement, compound 4: no gap at the digits printed; the measured number falls inside the stated range.
By their numbers in this assay, from the lowest: compounds 4, 2 and 3 (each within the scatter of the next).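

This swap gives the set its first step between two compounds that differ in one place: in this assay, putting trifluoromethyl in place of fluoro on an aromatic carbon, meta to a large group, gives a 1.5-fold lower number from compound 2 to compound 4 (0.18 log units; within the scatter). The two compounds cannot be told apart in this assay, even though the entering trifluoromethyl has 4 heavy atoms and the leaving fluoro has 1 heavy atom, so at this place on the ring a larger group can stand in for a smaller one without a step beyond the scatter. Nothing among the available data bears on why these two compounds read alike, so no explanation can be offered.

The compounds shown leave open what other groups at this same place would give, such as an amine, a carboxylic acid or a longer chain, and whether any of them would produce a step beyond the scatter. They also leave open how the same two groups would read at another carbon of the aromatic ring, and what a plain ring with only hydrogen there would give.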